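A few compounds are considered here, and "the series" means these few. Any claim that something is new, unique, unknown or untested is made for them only; others in the source may bear on it.

Compound 2 `O=C(Nc1ccc(F)cc1)c1cncc(N2CC3CC(C2)N3)c1` holds the lowest number of the two measured in an assay on membranes from Cerebral cortex for displacement of a labelled ligand from Neuronal acetylcholine receptor; alpha4/beta2 (Rattus norvegicus) (a lower number here means a stronger inhibitor, a higher number a weaker inhibitor), at 0.01 nM; compound 1 `O=C(Nc1ccccc1F)c1cncc(N2CC3CC(C2)N3)c1` gives 0.315 nM, and a 32-fold lower number from compound 1 to compound 2 (1.50 log units; beyond the scatter) marks that gap, with 4-fluorophenyl in place of 2-fluorophenyl on an amide-type nitrogen. Compound 3 `O=C(Nc1ccccc1)c1cncc(N2CC3CC(C2)N3)c1` differs from compound 2 by hydrogen in place of fluoro on an aromatic carbon para to a large group. Within the data shown here, no measured step removes a fluoro; the single step bears only on its position, so the direction stays open. Compound 3 is expected near 0.03 nM, within 0.005 nM to 0.2 nM. The step so expected is a 3.0-fold higher number from compound 2 to compound 3 (0.48 log units; beyond the scatter), a modest one.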

Compound 3, inhibition constant: 1.1 nM
The estimate for compound 3 lay 37-fold (1.56 log units) below the measured number; the measured number lies above the stated range.
By their numbers in this assay, from the lowest: compound 2; then compound 1; then compound 3.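

Hydrogen in place of fluoro is costly at both sites in this assay, so the fluoro itself matters and not only where it sits. At the site para to a large group the loss is large, with a 110-fold higher number from compound 2 to compound 3 (2.04 log units; beyond the scatter), while the 2-fluorophenyl to phenyl change is modest, with a 3.5-fold higher number from compound 1 to compound 3 (0.54 log units; beyond the scatter). No evidence given here accounts for these differences. On these data alone, whether a chloro or a methoxy group in place of the para fluoro would keep the low number stays open. So does whether a second fluoro on the same ring would add to it.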